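The source may report more compounds than this note shows. Statements on the series, on what has been measured and on what is new or still open speak of the compounds shown alone.

Compound 1 `CC1(Cc2cccc(/C(N)=N/O)c2)CC(S(=O)(=O)c2ccc(F)cc2)=C(c2ccc(/C(N)=N/O)cc2)O1` gives 50200 nM in an ADME assay on cells (Peritoneal macrophage, Mus musculus, strain Balb/c) for cytotoxicity, read by resazurin assay, with a stated time of 72 h; on this read-out lower numbers stand for higher toxicity in this test and higher numbers for lower toxicity in this test.
Compound 2 `CC1(Cc2ccc(CO)cc2)CC(S(=O)(=O)c2ccc(F)cc2)=C(c2ccc(/C(N)=N/O)cc2)O1` gives > 100000 nM in this assay; that reading is a limit of the assay and not a number.

Compound 2 therefore stands at the edge of what this assay can report, with only a limit known for it. Among the measured compounds shown here, the one measured step, an at least 1.9-fold higher number from compound 1 to compound 2 (0.29 log units; that floor lies within the scatter), is a floor rather than a size, and it sits at the limit of > 100000 nM in this assay, at which 1 of the 2 values shown sits.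

Compound 3 `CC1(Cc2ccccc2Br)CC(S(=O)(=O)c2ccc(F)cc2)=C(c2ccc(/C(N)=N/O)cc2)O1` differs from compound 2 by 2-bromophenyl in place of 4-(hydroxymethyl)phenyl on a saturated chain carbon bound to a saturated ring carbon. For the measured compounds named here, no measured step bears directly on this change: the only step known runs from compound 1 to compound 2 and swaps a different group at that position, so the size of the effect of the bromophenyl group cannot be read from the data. Compound 3 is expected to remain in the weakly toxic range that compound 1 and compound 2 occupy, and the step of an at least 1.4-fold lower number from compound 2 to compound 3 (0.15 log units; that floor lies within the scatter) is expected to stay within the scatter. The estimate for compound 3 in this assay is 70000 nM, with a range from 25000 nM to 200000 nM.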

Compound 3, half-maximal cytotoxic concentration: 109000 nM
Compound 3: middle estimate off by 1.6-fold (0.19 log units), on the low side, and the stated range covers the measured number.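

On the saturated chain carbon bound to a saturated ring carbon, this assay now holds a step of readable size, where the earlier step was only a floor within the scatter: a 2.2-fold higher number from compound 1 to compound 3 (0.34 log units; beyond the scatter), a modest change. The group entering at this place, 2-bromophenyl, counts 0 hydrogen-bond donors and 0 hydrogen-bond acceptors, so a high number here does not depend on the 1 donor and 1 acceptor of the 4-(hydroxymethyl)phenyl group, and a halogen-bearing ring is tolerated as well as the alcohol-bearing one in the sense that neither falls toward the number of the first compound. The size of the step between the 2-bromobenzyl and 4-(hydroxymethyl)benzyl compounds cannot be read, because compound 2 is known only through a limit of the assay: the limit of > 100000 nM in this assay, at which 1 of the 3 values shown sits.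

Still open, from the compounds shown here alone, is whether the bromine contributes anything at all, since a plain benzyl group at this place would be needed to separate its share from that of the ring. Going by these compounds, it is equally open how the number would respond to an amine or a carboxylic acid on that ring, or to a longer chain between the ring and the core.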